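The source may hold more compounds than are shown below. What is called first, only, known or untested is meant among the compounds shown, and "the series" means these compounds.

Compound 1 `COc1ccc2[nH]cc(/C=C(\C#N)C(=O)c3c[nH]c4ccccc34)c2c1`: in a functional assay on PC-3 cells (Homo sapiens) for cytotoxicity, read by WST assay, with a stated time of 24 h (on this read-out higher numbers stand for weaker inhibition and lower numbers for stronger inhibition), compound 1 gives 33200 nM.
Compound 2 `COc1ccc2[nH]cc(/C=C(\C#N)C(=O)c3c[nH]c4ccc(OC)cc34)c2c1`: in this assay compound 2 reaches only a limit of the assay, > 50000 nM.
Compound 3 `N#C/C(=C\c1c[nH]c2cc(F)ccc12)C(=O)c1c[nH]c2ccccc12`: in this assay compound 3 likewise reaches only a limit of the assay, > 50000 nM.

Compound 1 and compound 2 share a core and differ in one place, (methoxy in place of hydrogen on an aromatic carbon). That change made an at least 1.5-fold higher number from compound 1 to compound 2 (0.17 log units; that floor lies within the scatter), a step whose size is known only as a floor because of the limit of > 50000 nM in this assay, at which 2 of the 3 values shown sit. Compound 4 `COc1ccc2c(C(=O)/C(C#N)=C/c3c[nH]c4cc(F)ccc34)c[nH]c2c1` has not yet been measured in this assay. It differs from compound 3 by methoxy in place of hydrogen on an aromatic carbon, the same change made once more, on a place described in the same words. The difference between the core of compound 1 and the core of compound 3 is not broken down here.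

Within the data shown here, compound 3 already stands at a limit in this assay, and the one earlier step with this change ran toward weaker inhibition, so the step to compound 4 is expected to be a step that the limit leaves unreadable from compound 3 to compound 4, set beside an at least 1.5-fold higher number from compound 1 to compound 2 (0.17 log units; that floor lies within the scatter). Compound 4 is therefore expected to give an estimated 75000 nM, between 40000 nM and 160000 nM, most likely reported only as a limit.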

Compound 4, half-maximal inhibitory concentration: 36000 nM
Beside the measured number, compound 4's estimate is 2.1-fold (0.32 log units) above it; measured number outside the range, below it.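

In this assay, putting methoxy in place of hydrogen on an aromatic carbon made an at least 1.3-fold lower number from compound 3 to compound 4 (0.14 log units; that floor lies within the scatter). Set beside the earlier use of this change, the new step does not settle whether methoxy acts alike or differently on the two cores: the same change on two cores in this assay, an at least 1.5-fold higher number (0.17 log units; that floor lies within the scatter) from compound 1 to compound 2 and an at least 1.3-fold lower number (0.14 log units; that floor lies within the scatter) from compound 3 to compound 4; the limit leaves it open whether they differ Both steps are known only as floors, so the series shows neither a shared effect nor one that depends on the core, and a direction seen on one core cannot safely be carried to the other: the limit of > 50000 nM in this assay, at which 2 of the 4 values shown sit.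

The compounds shown leave open what other groups would do in this place, such as a hydroxyl, an amine or a longer chain like ethoxy. They also leave open how large the methoxy change really is, which would take a pair in which both compounds give a measured number rather than a limit in this assay.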